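Cutting the amide side group from a compound at the limit

A few compounds are considered here, and "the series" means these few. Any claim that something is new, unique, unknown or untested is made for them only; others in the source may bear on it.

Compound 2 (`Cc1c(C)c2c(c(C)c1OC(=O)CCC(=O)O)CCC(C)(C(=O)NCC1CC(C)(C)N([O])C1(C)C)O2`) gives > 300000 nM in a functional assay on RPMI-8226 cells (Homo sapiens) for cytotoxicity, read by MTT assay, with a stated time of 72 h (a higher number here means a weaker inhibitor, a lower number a stronger inhibitor), and this is a limit, not a number. Compound 1 (`Cc1c(C)c2c(c(C)c1OC(=O)CCC(=O)O)CCC(C)(C(=O)NC1CC(C)(C)N([O])C(C)(C)C1)O2`) gives > 300000 nM in this assay, again a limit. Among the compounds with values here, the one measured change is a step that the two limits leave unreadable from compound 1 to compound 2, so it offers no size to carry forward. All the evidence so far is the limit of > 300000 nM in this assay, at which 2 of the 2 values shown sit, which shows no graded trend. Going to compound 3 (`Cc1c(C)c2c(c(C)c1OC(=O)CCC(=O)O)CCC(C)(C(=O)O)O2`) removes the whole ring-bearing amide group and leaves a hydroxy on the carbonyl carbon: one oxygen atom in place of a group of 12 heavy atoms (9 carbon, 2 nitrogen, 1 oxygen; one five-membered non-aromatic ring with 1 hetero atom), on a carbonyl carbon. The expectation rests on the limit of compound 2 at > 300000 nM, and no step beyond the scatter is expected in this assay in either direction. The expected size is a number no higher from compound 2 to compound 3 (the limit leaves the size open), a rough figure. Compound 3 is estimated at 300000 nM, with an expected range from 100000 nM to 1000000 nM, and a reading reported only as a limit is likely.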

Compound 3, half-maximal inhibitory concentration: 63000 nM
Beside the measured number, compound 3's estimate is 4.8-fold (0.68 log units) above it; the measured number lies below the stated range.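

Within the data shown here, compound 3 is the first compound here to give a number rather than a limit in this assay, so a change on this carbonyl carbon can now be read. Putting hydroxy in place of the ring-bearing amide group gives an at least 4.7-fold lower number from compound 2 to compound 3 (0.67 log units; beyond the scatter), and the same swap for the amide with the six-membered ring gives an at least 4.7-fold lower number from compound 1 to compound 3 (0.67 log units; beyond the scatter). Each step starts from a limit, so its true size stays open, and both amides remain at the same limit: the limit of > 300000 nM in this assay, at which 2 of the 3 values shown sit.

The compounds shown do not separate the loss of the ring from the loss of the amide itself. A small methyl amide on this carbonyl carbon would sit between those two changes, and a methyl ester would show what replacing the hydroxy alone does.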